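The source may report more compounds than this note shows. Statements on the series, on what has been measured and on what is new or still open speak of the compounds shown alone.

Compound 1 `O=C1CCC(N2C(=O)c3ccc(Nc4ccccc4)cc3C2=O)C(=O)N1` and compound 2 `O=C1CCC(N2C(=O)c3ccc(Nc4ccccn4)cc3C2=O)C(=O)N1` share one core; in an assay on FRT-Jurkat cells for inhibition of nuclear factor NF-kappa-B complex (Homo sapiens), read by flow cytometry, with a stated time of 24 h, tested at 10 uM (a higher number here means more inhibition at the concentration tested (going by the name of the read-out), a lower number less inhibition), compound 1 gives 6%, while compound 2 gives 9%. Compound 1 stands at the low end of the two numbers shown, yet the step of a number 3 percentage points higher from compound 1 to compound 2 (within the scatter) lies within the scatter, so the two are not told apart. Compound 3 `CCCCCc1ccc(Nc2ccc3c(c2)C(=O)N(C2CCC(=O)NC2=O)C3=O)cc1` is compound 1 with pentyl in place of hydrogen on an aromatic carbon. For the measured compounds named here, the only measured step concerns a different place and was small, so it offers little guidance. A step of a number 2 percentage points higher from compound 1 to compound 3 (within the scatter) with nothing beyond the scatter is therefore expected. Compound 3 is estimated at 8%, between -5% and 25%.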

Compound 3, a percentage reported as inhibition, at one concentration (the size of the read-out at that concentration, not a potency): 12%
Estimate against measurement, compound 3: 4 percentage points below; the measured number falls inside the stated range.
By their numbers in this assay, from the lowest: compounds 1, 2 and 3 (each within the scatter of the next).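

At this position, on an aromatic carbon para to a large group, the shared core carries a pentyl chain with no change that can be told from the scatter: in this assay the result is a number 6 percentage points higher from compound 1 to compound 3 (within the scatter). Adding this chain therefore does not separate compound 3 from compound 1 at the concentration tested. Nothing available explains this result. From the compounds shown here alone, whether an amine, a carboxylic acid or a longer chain at this position would give a step beyond the scatter remains open. So does whether pentyl would act the same way on the pyridin-2-yl group of compound 2.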